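The source may hold more compounds than are shown below. What is called first, only, known or untested is meant among the compounds shown, and "the series" means these compounds.

In an ADME assay on RAW264.7 cells (Mus musculus) for cytotoxicity, read by WST assay, with a stated time of 24 h (a lower number here means a stronger inhibitor of growth, a higher number a weaker inhibitor of growth), compound 1 (`CCOC(=O)c1cn(-c2c([N+](=O)[O-])ncn2C)nn1`) gives > 376000 nM. That value is a limit of the assay and not a number, so compound 1 has no exact position on the scale. Among the compounds with values here, the only exact number so far belongs to compound 2 (`CCCCCc1ccc(-c2cn(-c3c([N+](=O)[O-])ncn3C)nn2)cc1`), at 35800 nM. Compound 3 (`Cn1cnc([N+](=O)[O-])c1-n1cc(C2CC2)nn1`) keeps the core of compound 1 but has cyclopropyl in place of ethoxycarbonyl on an aromatic carbon. Within the data shown here, no measured pair shows what this kind of swap does, so the expectation is loose. Only a modest move towards lower numbers is expected, or none beyond the usual scatter, and the assay may again report only a limit. The estimated change is an at least 1.2-fold lower number from compound 1 to compound 3 (0.09 log units; that floor lies within the scatter). For compound 3 the estimated value is 300000 nM, with an expected range from 110000 nM to 430000 nM.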

Compound 3, concentration for 50% growth inhibition: > 427000 nM
Compound 3: only a limit was reported; the forecaster's own chance of this, stated with the estimate: 60%; middle value at least 1.4-fold (0.15 log units) away from the limit.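

In this assay compound 1 gives > 376000 nM as a limit and not a number. Compound 3 gives > 427000 nM as a limit too. Within the data shown here, with only these two limits, no step from compound 1 to compound 3 can be read. Going by these compounds, whether cyclopropyl in place of ethoxycarbonyl changes the reading in this assay at all remains open.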